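Replacing a Protected Sugar with a Free One

This account rests on a few compounds, and the source may have more. Where it says the series, first, only, none or still open, it means among the compounds named here.

Two compounds share one core and differ only in the group that hangs from one of its nitrogens. Compound 1 `CN1CCN(CCCCCn2c3c(c4ccccc42)C(=O)c2c[n+]([O-])c4ccccc4c2C3=O)CC1` carries a flexible chain ending in a second ring; in a functional assay on A549 cells (Homo sapiens) for cytotoxicity, read by MTT assay, with a stated time of 72 h (a lower number here means a stronger inhibitor, a higher number a weaker inhibitor), compound 1 gives 870 nM. Compound 2 `CC1(C)O[C@@H](CO)[C@H](Cn2cc(Cn3c4c(c5ccccc53)C(=O)c3c[n+]([O-])c5ccccc5c3C4=O)nn2)O1` carries instead a five-membered aromatic ring with 3 nitrogen that bears a (5-(hydroxymethyl)-2,2-dimethyl-1,3-dioxolan-4-yl)methyl group; in this assay compound 2 gives 370 nM, the lowest of the two numbers, and its gap to compound 1 lies beyond the usual scatter.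

Compound 3 `O=C1c2c[n+]([O-])c3ccccc3c2C(=O)c2c1c1ccccc1n2Cc1cn([C@@H]2O[C@H](CO)[C@@H](O)[C@H](O)[C@H]2O)nn1` has not yet been measured. It differs from compound 2 in one place: 3,4,5-trihydroxy-6-(hydroxymethyl)oxan-2-yl in place of (5-(hydroxymethyl)-2,2-dimethyl-1,3-dioxolan-4-yl)methyl on an aromatic nitrogen. Among the measured compounds shown here, no measured pair in this set shows what such a change does to the read-out, so the expectation rests on compound 2 alone and carries real uncertainty. The estimated step is small, a 1.8-fold higher number from compound 2 to compound 3 (0.24 log units; within the scatter), most likely a modest weakening, though a move within the scatter in either direction would not surprise. Compound 3 is expected to give about 650 nM in this assay, with a range from 220 nM to 2000 nM.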

Compound 3, half-maximal inhibitory concentration: 560 nM
Estimate against measurement, compound 3: 1.2-fold (0.06 log units) above, and the stated range covers the measured number.
By their numbers in this assay, from the lowest: compounds 2, 3 and 1 (each within the scatter of the next, the first and the last beyond it).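

On an aromatic nitrogen of the five-membered aromatic ring with 3 nitrogen, putting 3,4,5-trihydroxy-6-(hydroxymethyl)oxan-2-yl in place of (5-(hydroxymethyl)-2,2-dimethyl-1,3-dioxolan-4-yl)methyl gives, in this assay, a 1.5-fold higher number from compound 2 to compound 3 (0.18 log units; within the scatter) and so leaves the two compounds indistinguishable. Among the compounds shown here, this is the first pair here that differs in one place, and it shows that this position accepts a clear change in the group: a six-membered ring with 1 hetero atom replaces a five-membered one with 2, and 4 hydrogen-bond donors replace 1, with no step beyond the scatter. No measurement of any property of these two groups accompanies the result, so nothing can be said about what lies behind it.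

One pair in one assay cannot show how far this acceptance extends, or whether it would hold for a sugar with its hydroxyl groups capped as acetates or for a longer chain between the sugar and the ring. An amine or a carboxylic acid on the same nitrogen also remains an open case, and either could read quite differently.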